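A Methoxy Added to a Compound Tolerated at the Limit

The source may hold more compounds than are shown below. What is called first, only, known or untested is meant among the compounds shown, and "the series" means these compounds.

Compound 1 `Sc1nc(NCc2ccccc2)c2ccccc2n1` carries a thiol and a benzylamine on the shared core. In a functional assay on HT-29 cells (Homo sapiens) for cytotoxicity, read by MTT assay, with a stated time of 72 h (a higher number here means that more compound is tolerated, a lower number that less compound is tolerated), compound 1 gives > 100000 nM, which is a limit of the assay and not a number. Compound 2 `C[Se]c1nc(NCc2ccccc2)c2ccccc2n1` carries a methylseleno group instead of the thiol. In this assay compound 2 gives > 100000 nM, again only a limit. The step that the two limits leave unreadable from compound 1 to compound 2 is for that reason unreadable, as both values sit at the limit of > 100000 nM in this assay, at which 2 of the 2 values shown sit. Compound 3 `COc1ccc(CNc2nc(S)nc3ccccc23)cc1` is still to be measured. It differs from compound 1 by methoxy in place of hydrogen on an aromatic carbon. Among the compounds with values here, no measured step touches the benzyl ring, so nothing known says how large a change in this assay the methoxy brings. Both known values are limits, and compound 3 is expected to stay near that limit. The step of a number no higher from compound 1 to compound 3 (the limit leaves the size open) is estimated to be small. Compound 3 is therefore expected to give 100000 nM, within a range from 30000 nM to 300000 nM.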

Compound 3, concentration lethal to 50% of the cells: 63900 nM
The estimate for compound 3 lay 1.6-fold (0.19 log units) above the measured number, within the range that was stated.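

In this assay compound 3 gives 63900 nM, the only value among the compounds shown that is a number and not a limit. Methoxy in place of hydrogen, para to a large group, brings an at least 1.5-fold lower number from compound 1 to compound 3 (0.19 log units; that floor lies within the scatter); the true step may be larger than this floor, but the floor alone does not show a change beyond the usual scatter. Any reading of this position therefore rests on a single number set against a limit: the limit of > 100000 nM in this assay, at which 2 of the 3 values shown sit.

The compounds shown leave open whether a hydroxyl group, a chlorine atom or a longer chain such as ethoxy at this place on the benzyl ring would give a number clearly lower than the limit. They also leave open whether methoxy would bring a similar step on compound 2, which carries the methylseleno group.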